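The source may report more compounds than this note shows. Statements on the series, on what has been measured and on what is new or still open speak of the compounds shown alone.

The measured compounds and what they gave:

Compound 1, `CCCCNCCCCOc1c(O)cc(O)c2c(=O)cc(-c3ccccc3)oc12`, in a functional assay on A549 cells (Homo sapiens) for cytotoxicity, read by MTT assay, with a stated time of 48 h; a lower number here means a stronger inhibitor, a higher number a weaker inhibitor: "not determined" (no result reported)
Compound 2, `CC(C)NCCOc1c(O)cc(O)c2c(=O)cc(-c3ccccc3)oc12`, in this assay: "not determined" (no result reported)
Compound 3, `CN1CCN(CCCOc2c(O)cc(O)c3c(=O)cc(-c4ccccc4)oc23)CC1`, in this assay: > 100000 nM

Of the three compounds with entries in this assay, only compound 3 carries anything that can be placed, and even that is not a number. In this assay compound 3 sits at a limit, > 100000 nM, which is the end of the measured range rather than a value; this is recorded as the limit of > 100000 nM in this assay, at which 1 of the 3 values shown sits. Among the measured compounds shown here, compound 1 and compound 2 have no result in this assay at all, so no step between measured compounds can be drawn, and compound 3 cannot be ranked against anything.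

The next compound, compound 4, is `CN(C)CCCOc1c(O)cc(O)c2c(=O)cc(-c3ccccc3)oc12`. It differs from compound 3 in one place: dimethylamino in place of 4-methylpiperazin-1-yl on a saturated chain carbon, three bonds along the chain from an oxygen on an aromatic ring.

For the measured compounds named here, with compound 3 already at the limit of this assay and no measured step to lean on, the size of the change from compound 3 to compound 4 cannot be read from the data; the expectation is a step of a number no higher from compound 3 to compound 4 (the limit leaves the size open), that is, none beyond the scatter. For compound 4 in this assay the estimate is 100000 nM, with a range from 30000 nM to 300000 nM, and a good chance that only a limit is reported again.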

Compound 4, half-maximal inhibitory concentration: > 100000 nM
Compound 4: a limit, no number; the forecaster's own chance of this, stated with the estimate: 60%; the middle value sits exactly at the limit.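

Compound 3 and compound 4 both stand at a limit in this assay and not at a number, so no step can be read between them: the limit of > 100000 nM in this assay, at which 2 of the 4 values shown sit.

The compounds shown leave open whether dimethylamino and 4-methylpiperazin-1-yl differ at all in this place, and where either compound would stand against a compound with a number in this assay.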